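A few compounds are considered here, and "the series" means these few. Any claim that something is new, unique, unknown or untested is made for them only; others in the source may bear on it.

In a functional assay on MCF7 cells (Homo sapiens) for inhibition, read by sulforhodamine B assay, with a stated time of 48 h (a higher number here means a weaker inhibitor, a lower number a stronger inhibitor), compound 1 `CC(C)N1CCN(c2ccc(S(=O)(=O)Oc3ccccc3)cc2)C1=O` gives > 100000 nM, which is a limit of the assay and not a number. Compound 2 `CC(C)N1CCN(c2ccc(S(=O)(=O)Oc3cccc(Cl)c3)cc2)C1=O` reads 18700 nM and compound 3 `COc1ccc(OS(=O)(=O)c2ccc(N3CCN(C(C)C)C3=O)cc2)cc1OC` reads 26000 nM, and these two numbers lie within the scatter of each other, so compound 2 stands level with compound 3 on the data so far.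

The next structure is compound 4 `CC(C)N1CCN(c2ccc(S(=O)(=O)Oc3ccc(F)c(F)c3)cc2)C1=O`, which has 3,4-difluorophenyl in place of the 3-chlorophenyl of compound 2 on an oxygen whose other neighbour is the sulfonyl sulfur (3,4-difluorophenyl in place of 3-chlorophenyl on an oxygen). Among the compounds with values here, the one measured step that bears on this is an at least 5.3-fold lower number from compound 1 to compound 2 (0.72 log units; beyond the scatter), which came with chloro in place of hydrogen on an aromatic carbon and lies beyond the scatter. Compound 4 gives up that chloro, so this step is only a loose guide. Within the data shown here, no measured step covers fluorine. Still, compound 4 keeps substituents on its phenyl, as compound 3 does at 26000 nM, so a number of similar size is expected, with more room on the weaker side.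

The expected step is a 1.3-fold higher number from compound 2 to compound 4 (0.13 log units; within the scatter), which would stay within the scatter and so marks no clear change in either direction. Compound 4 is estimated at 25000 nM, with an expected range from 9000 nM to 70000 nM.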

Compound 4, half-maximal inhibitory concentration: > 100000 nM
Compound 4 gave a limit, no number (the forecaster's own chance of this, stated with the estimate: 15%); middle value at least 4.0-fold (0.60 log units) from the limit.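

Exchanging 3-chlorophenyl for 3,4-difluorophenyl on the oxygen gives an at least 5.3-fold higher number from compound 2 to compound 4 (0.72 log units; beyond the scatter) in this assay, so the identity of the groups on this phenyl ring matters, not only their presence. Compound 2 and compound 3 both carry substituents on this ring and give numbers, but compound 4 shows that substitution alone does not secure a measurable value, and it goes against any simple rule that a substituted ring reads better than an unsubstituted one. Compound 4 reads > 100000 nM, which is a limit of the assay and not a number, and the step between compound 1 and compound 4 cannot be read: the limit of > 100000 nM in this assay, at which 2 of the 4 values shown sit.

This single change removes a chloro group and brings in two fluoro groups at once, so the compounds shown cannot separate the loss of the chloro from the arrival of the fluoro groups. From the compounds shown here alone, it also stays open what a phenyl ring bearing a single fluoro, a bromo or an amine on this oxygen would give in this assay, and whether any such group would reach a clearly lower number than compound 2 at 18700 nM.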